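A few compounds are considered here, and "the series" means these few. Any claim that something is new, unique, unknown or untested is made for them only; others in the source may bear on it.

Measured so far in a physicochemical assay for lipophilicity, measured as octanol-water partition, with a stated time of 72 h; a higher number here means a more lipophilic compound, a lower number a more polar compound:
- compound 1 `CC(C)NC(=O)NO`: 0.2
- compound 2 `CN(O)C(N)=O`: -0.46

Compound 2, at -0.46, holds the lower of the two numbers, and compound 1 lies above it by more than the usual scatter. Compound 3 `CCN(O)C(N)=O` differs from compound 2 by methyl in place of hydrogen on a saturated chain carbon bound to an amide-type nitrogen, which reads as methyl to ethyl. Going by the values given here, no measured pair shows a change of this kind, so the expectation rests on the structural change alone: a modest rise in this assay, just beyond the scatter. The expected change is a number 0.41 log units higher from compound 2 to compound 3 (beyond the scatter). For compound 3 the estimated value is -0.05, with an expected range of -0.35 to 0.25.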

Compound 3, partition coefficient: -0.1
Compound 3: the middle estimate sits 0.05 log units above what was measured, within the range that was stated.
By their numbers in this assay, from the lowest: compound 2; then compounds 3 and 1 (each within the scatter of the next).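

Methyl in place of hydrogen on a saturated chain carbon bound to an amide-type nitrogen gives a number 0.36 log units higher from compound 2 to compound 3 (beyond the scatter) in this assay, a modest step and the only one that can be read so far. It shows that this position responds measurably to the change from methyl to ethyl. Nothing available explains the size of this step. One step leaves open whether a longer chain, such as propyl, would move the number further in the same direction. As far as these compounds go, how an amine or a carboxylic acid on this chain would read also remains open.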